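A few compounds are considered here, and "the series" means these few. Any claim that something is new, unique, unknown or untested is made for them only; others in the source may bear on it.

In a functional assay on SK-OV-3 cells (Homo sapiens) for inhibition, read by CCK-8 assay, with a stated time of 70 h (a higher number here means a weaker inhibitor, a lower number a stronger inhibitor), compound 1 (`c1ccc(COc2ccc(OCCOCCOC3CCCC3)cc2)cc1`) gives > 100000 nM, which is a limit of the assay and not a number. Among the measured compounds shown here, compound 2 (`c1ccc(COc2ccc(OCCOCCNc3cc[nH]c3)cc2)cc1`) gives 11300 nM, the only actual number so far in this short series. Compound 3 (`c1ccc(COc2ccc(OCCOCCNC3CCCCCC3)cc2)cc1`) has cycloheptyl in place of 1H-pyrrol-3-yl on an amine nitrogen. For the measured compounds named here, the sole measured step bearing on this is an at least 8.8-fold lower number from compound 1 to compound 2 (0.94 log units; beyond the scatter), and its size is bounded by the limit of > 100000 nM in this assay, at which 1 of the 2 values shown sits. That step replaced cyclopentyloxy with (1H-pyrrol-3-yl)amino, so it does not separate the amine nitrogen from the ring on it, whereas compound 3 keeps that nitrogen and changes only the ring. On this evidence, no direction can be assigned in this assay, and no step beyond the scatter is expected. The estimated step is a 1.4-fold lower number from compound 2 to compound 3 (0.15 log units; within the scatter). For compound 3 the expected value is 8000 nM, with an estimated range of 2000 nM to 40000 nM.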

Compound 3, half-maximal inhibitory concentration: 7460 nM
Beside the measured number, compound 3's estimate is 1.1-fold (0.03 log units) above it; the measured number falls inside the stated range.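

In this assay, 1H-pyrrol-3-yl on the amine nitrogen gives way to cycloheptyl without a step beyond the scatter (a 1.5-fold lower number from compound 2 to compound 3 (0.18 log units; within the scatter)), so a ring with no aromatic character and no hydrogen-bond donor serves as well here as the five-membered aromatic ring. A second amine now stands clearly apart from the cyclopentyloxy compound (an at least 13-fold lower number from compound 1 to compound 3 (1.12 log units; beyond the scatter)), which puts both amines shown on the same side of that step. The value of compound 1 is a limit and not a number, so the size of that step has only a bound: the limit of > 100000 nM in this assay, at which 1 of the 3 values shown sits.

Compound 1 differs from both amines in the ring as well as in the linking atom, so the contribution of the amine nitrogen alone stays unresolved. Cyclopentylamino, an amide in place of the amine and a longer chain remain open in this assay.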